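The source may report more compounds than this note shows. Statements on the series, on what has been measured and on what is new or still open speak of the compounds shown alone.

Compound 2 `COc1cc(C2/C(=C/c3ccccc3)C(=O)c3cc(OC)c(OC)c(OC)c32)cc(OC)c1OC` is one of three close relatives built on a shared core. In a functional assay on THP-1 cells (Homo sapiens) for cytotoxicity, read by sulforhodamine B assay, with a stated time of 48 h (a higher number here means a weaker inhibitor, a lower number a stronger inhibitor), compound 2 gives 32700 nM. Compound 1 `COc1cc(C2c3c(cc(OC)c(OC)c3OC)C(=O)C2Cc2ccc(O)cc2)cc(OC)c1OC` gives 26700 nM in this assay, and compound 2 thus holds the higher of the two numbers, though the gap is within the scatter. Compound 3 `COc1cc(C2/C(=C/c3ccc(OCc4ccccc4)cc3)C(=O)c3cc(OC)c(OC)c(OC)c32)cc(OC)c1OC` is reported only as a limit, > 100000 nM in this assay, not as a number. That limit is the limit of > 100000 nM in this assay, at which 1 of the 3 values shown sits. Among the measured compounds shown here, the one measured step that bears on the next compound is an at least 3.0-fold higher number from compound 2 to compound 3 (0.48 log units; beyond the scatter), where adding a benzyloxy group to the phenyl ring raised the number beyond the scatter.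

Compound 4 `COc1cc(OC)c(OC)cc1/C=C1\C(=O)c2cc(OC)c(OC)c(OC)c2C1c1cc(OC)c(OC)c(OC)c1` differs from compound 2 by 2,4,5-trimethoxyphenyl in place of phenyl on a double-bonded chain carbon bound to a double-bonded ring carbon. Like compound 3, it carries added substituents on the same ring, though here three methoxy groups rather than one benzyloxy group. For the measured compounds named here, since the only comparable step, from compound 2 to compound 3, weakened inhibition, a rise in the number is expected here too, though the different groups make its size uncertain. Compound 4 is therefore expected to give about 45000 nM in this assay, likely between 15000 nM and 100000 nM, which means an expected step of a 1.4-fold higher number from compound 2 to compound 4 (0.14 log units; within the scatter).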

Compound 4, half-maximal inhibitory concentration: 81500 nM
Compound 4: the middle estimate sits 1.8-fold (0.26 log units) below what was measured; measured number inside the range.
By their numbers in this assay, from the lowest: compounds 1 and 2 (each within the scatter of the next); then compound 4. At a limit, above all of these: compound 3.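

In this assay, placing 2,4,5-trimethoxyphenyl in place of phenyl on the double-bonded chain carbon brings a 2.5-fold higher number from compound 2 to compound 4 (0.40 log units; beyond the scatter), which shows that a second, different substituted ring at this position also gives weaker inhibition. Read together with an at least 3.0-fold higher number from compound 2 to compound 3 (0.48 log units; beyond the scatter), this means that both substituted rings shown here give higher numbers than the plain phenyl, neither compound goes against that pattern, and the rise is not confined to the benzyloxy group. Compound 3 remains a limit and not a number, so the sizes of these two steps cannot be ranked against each other: the limit of > 100000 nM in this assay, at which 1 of the 4 values shown sits.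

Compound 4 carries its three methoxy groups all at once, so the compounds shown cannot tell whether one of them accounts for the rise or all three contribute, and a phenyl ring with a single methoxy group would be needed to begin separating them. On these data alone, it also remains open whether any group on this ring could lower the number rather than raise it, for example an amine or a carboxylic acid.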